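Triazole series: hydroxymethoxyphenyl ketone on the dimethylaminophenyl core

The compounds below may be only part of what the source reports. "The series", "measured", "known", "first", "only" and "open" are said of these compounds alone.

Compound 1 `COc1ccc(-n2c(SCC(=O)c3ccc(F)cc3)nnc2-c2cc(OC)c(OC)c(OC)c2)cc1` gives 10700 nM in a functional assay on HepG2 cells (Homo sapiens) for inhibition, read by MTT assay, with a stated time of 48 h; on this read-out lower numbers stand for stronger inhibition and higher numbers for weaker inhibition. Compound 2 `COc1ccc(-n2c(SCC(=O)c3ccc(OC)c(O)c3)nnc2-c2cc(OC)c(OC)c(OC)c2)cc1` returns only a limit of this assay, > 60000 nM. Compound 3 `COc1cc(-c2nnc(SCC(=O)c3ccc(F)cc3)n2-c2ccc(N(C)C)cc2)cc(OC)c1OC` likewise returns only a limit, > 60000 nM. The step of an at least 5.6-fold higher number from compound 1 to compound 2 (0.74 log units; beyond the scatter) comes with 3-hydroxy-4-methoxyphenyl in place of 4-fluorophenyl on a carbonyl carbon, and the step of an at least 5.6-fold higher number from compound 1 to compound 3 (0.74 log units; beyond the scatter) with dimethylamino in place of methoxy on an aromatic carbon. Compound 4 `COc1ccc(C(=O)CSc2nnc(-c3cc(OC)c(OC)c(OC)c3)n2-c2ccc(N(C)C)cc2)cc1O` is not yet measured; it differs from compound 3 by 3-hydroxy-4-methoxyphenyl in place of 4-fluorophenyl on a carbonyl carbon, the same change made from compound 1 to compound 2, at the same place. The two cores differ by dimethylamino in place of methoxy on an aromatic carbon. The step from compound 3 to compound 4 in this assay is expected to be no more favourable than the earlier one, given (the limit of > 60000 nM in this assay, at which 2 of the 3 values shown sit). Compound 4 is therefore estimated at 150000 nM, with a range from 60000 nM to 400000 nM, most likely reported as a limit only. For compound 4 this means an expected step that the limit leaves unreadable from compound 3 to compound 4.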

Compound 4, half-maximal inhibitory concentration: > 100000 nM
Compound 4: only a limit was reported; the forecaster's own chance of this, stated with the estimate: 90%; the middle value does not contradict the limit.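

In this assay compound 4 gives only a limit, > 100000 nM. Among the compounds shown here, compound 2 and compound 3 are limits too, so no step to compound 4 can be read. As far as these compounds go, how far 3-hydroxy-4-methoxyphenyl shifts the number on the core of compound 3 stays open.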